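Adding a Trifluoromethyl Group to a Coumarin Pyrazoline Series

A few compounds are considered here, and "the series" means these few. Any claim that something is new, unique, unknown or untested is made for them only; others in the source may bear on it.

The three measured compounds and their numbers in a functional assay on HepG2 cells (Homo sapiens) for cytotoxicity, read by MTT assay, with a stated time of 72 h (a lower number here means a stronger inhibitor, a higher number a weaker inhibitor), are:

Compound 1 `COc1ccc2ccc(=O)oc2c1C1=NN(C(N)=O)C(c2cccs2)C1`: 26 nM
Compound 2 `COc1ccc2ccc(=O)oc2c1C1=NN(C(C)=O)C(c2ccccc2)C1`: 52 nM
Compound 3 `COc1ccc2ccc(=O)oc2c1C1=NN(c2ccccc2)C(c2ccccc2)C1`: 73 nM

Compound 3 carries a phenyl on the ring nitrogen where compound 2 carries an acetyl; the step of a 1.4-fold higher number from compound 2 to compound 3 (0.15 log units; within the scatter) lies within the scatter, so compound 2 and compound 3 cannot be told apart on these numbers. Against compound 1, which gives 26 nM in this assay, compound 3 gives the higher number, and that gap does lie beyond the scatter.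

Compound 4 `COc1ccc2ccc(=O)oc2c1C1=NN(c2ccccc2)C(c2ccc(C(F)(F)F)cc2)C1` is built from compound 3 by one change: trifluoromethyl in place of hydrogen on an aromatic carbon. Among the measured compounds shown here, none of the measured steps touches this part of the molecule. For the measured compounds named here, the only step that is known, from compound 2 to compound 3, concerns the group on the ring nitrogen, not the phenyl on the ring carbon, so it says nothing about what a trifluoromethyl there will do. With no bearing evidence, the expected step of no change at the digits printed from compound 3 to compound 4 (within the scatter) is none beyond the scatter.

Compound 4 is therefore expected to give about 73 nM in this assay, with a plausible range from 25 nM to 220 nM.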

Compound 4, half-maximal inhibitory concentration: 38 nM
Compound 4: the middle estimate sits 1.9-fold (0.28 log units) above what was measured, within the range that was stated.
By their numbers in this assay, from the lowest: compounds 1, 4, 2 and 3 (each within the scatter of the next, the first and the last beyond it).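

This is the first of the compounds shown to change the phenyl on the ring carbon rather than the group on the ring nitrogen, and in this assay going from phenyl to 4-(trifluoromethyl)phenyl gives a 1.9-fold lower number from compound 3 to compound 4 (0.28 log units; within the scatter), so compound 3 and compound 4 cannot be told apart. This position therefore accepts a trifluoromethyl group without a shift that this assay can resolve, although this is a single group in a single molecular setting and does not establish a general rule. Nothing else available bears on this result, so it comes with no explanation.

Still open, going by these compounds, is whether a different group at this same place, such as an amine, a carboxylic acid or a longer chain, would also stay within the scatter of compound 3 or would move the number beyond it. Also open, on these data alone, is whether trifluoromethyl would give a similarly small step on compound 2, which carries an acetyl rather than a phenyl on the ring nitrogen.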